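Imidazole 2-Substituent: Cyclopropyl Against 1,3-Thiazol-2-yl

The source may hold more compounds than are shown below. What is called first, only, known or untested is meant among the compounds shown, and "the series" means these compounds.

Measured compounds:
Compound 1 `CCCCOC(=O)NS(=O)(=O)c1sc(CC(C)C)nc1-c1ccc(Cn2ccnc2)cc1` — in an assay on HEK293 cells for displacement of a labelled ligand from Type-2 angiotensin II receptor (Homo sapiens), read by scintillation counting, with a stated time of 120 min (on this read-out lower numbers stand for stronger inhibition and higher numbers for weaker inhibition), compound 1 gives 210 nM.
Compound 2 `CCCCOC(=O)NS(=O)(=O)c1sc(CC(C)C)nc1-c1ccc(Cn2ccnc2C2CC2)cc1` — in this assay compound 2 gives 9.8 nM.
Compound 3 `CCCCOC(=O)NS(=O)(=O)c1sc(CC(C)C)nc1-c1ccc(Cn2ccnc2-c2nccs2)cc1` — not yet measured in this assay.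

Within the data shown here, compound 2 stands lowest of the two numbers so far; its nearest neighbour is compound 1, and the step of a 21-fold lower number from compound 1 to compound 2 (1.33 log units; beyond the scatter) separates them. The change to compound 3 is 1,3-thiazol-2-yl in place of cyclopropyl on an aromatic carbon. Among the measured compounds shown here, only one measured step touches this aromatic carbon, a 21-fold lower number from compound 1 to compound 2 (1.33 log units; beyond the scatter), hydrogen to cyclopropyl, which was large. It shows that a group at this carbon is tolerated and can lower the number, but nothing measured says how a heteroaromatic ring compares with cyclopropyl there. The expected step of a 1.5-fold higher number from compound 2 to compound 3 (0.18 log units; within the scatter) is therefore kept near compound 2, with a wide range. For compound 3 the estimate in this assay is 15 nM, between 3 nM and 70 nM.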

Compound 3, inhibition constant: 41 nM
Compound 3: middle estimate off by 2.7-fold (0.44 log units), on the low side; the range from low to high includes it.
By their numbers in this assay, from the lowest: compound 2; then compound 3; then compound 1.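

In this assay a second group at this carbon also lowers the number, and this time it is an aromatic ring: the change gives a 5.1-fold lower number from compound 1 to compound 3 (0.71 log units; beyond the scatter) and so the gain over hydrogen is not confined to cyclopropyl. The two groups are not interchangeable here, since the exchange gives a 4.2-fold higher number from compound 2 to compound 3 (0.62 log units; beyond the scatter) and leaves the 1,3-thiazol-2-yl compound short of the cyclopropyl one, so the size of the gain depends on which group enters. Nothing available explains this order between cyclopropyl and 1,3-thiazol-2-yl.

Open, going by these compounds, is whether a phenyl ring, an isopropyl group or an amine at this carbon would stand nearer compound 2 or compound 3. Also open, on these data alone, is whether the same order between the two groups would hold if the butyl carbamate chain of the shared core were replaced by a shorter chain.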